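Thiophen-3-yl in place of 4-nitrophenyl on the carbonyl

The compounds below may be only part of what the source reports. "The series", "measured", "known", "first", "only" and "open" are said of these compounds alone.

Compound 1 `COc1ccc(-c2cc3ccccc3nc2/C=C/C(=O)c2ccc(F)cc2)cc1` gives 8320 nM in a functional assay on A549 cells (Homo sapiens) for antiproliferative activity, read by XTT assay, with a stated time of 72 h; on this read-out lower numbers stand for stronger inhibition and higher numbers for weaker inhibition. Compound 2 `COc1ccc(-c2cc3ccccc3nc2/C=C/C(=O)c2ccc([N+](=O)[O-])cc2)cc1` gives 6310 nM in this assay, the lowest of the two numbers, though a 1.3-fold lower number from compound 1 to compound 2 (0.12 log units; within the scatter) stays within the scatter. Compound 3 `COc1ccc(-c2cc3ccccc3nc2/C=C/C(=O)c2ccsc2)cc1` carries thiophen-3-yl in place of 4-nitrophenyl on a carbonyl carbon. Among the compounds with values here, the only measured step swaps one group for another on the same ring; none replaces the ring itself, so the data give no size for this change. For compound 3 a step within the scatter is expected, a 1.1-fold higher number from compound 2 to compound 3 (0.05 log units; within the scatter). Compound 3 is estimated at 7000 nM in this assay, with a range of 2500 nM to 20000 nM.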

Compound 3, half-maximal inhibitory concentration: 8210 nM
Compound 3: middle estimate off by 1.2-fold (0.07 log units), on the low side; the measured number falls inside the stated range.
By their numbers in this assay, from the lowest: compounds 2, 3 and 1 (each within the scatter of the next).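

On the carbonyl carbon, the whole ring can now be exchanged and not only its substituent: thiophen-3-yl for 4-nitrophenyl gives a 1.3-fold higher number from compound 2 to compound 3 (0.11 log units; within the scatter) in this assay, and thiophen-3-yl for 4-fluorophenyl gives a 1.0-fold lower number from compound 1 to compound 3 (0.01 log units; within the scatter). Both steps lie within the scatter, so these three groups are not told apart at this position. Nothing at hand gives a reason for this result.

On these data alone, it remains open whether an amine or a carboxylic acid on the phenyl ring, or a longer chain in place of the ring, would move the number beyond the scatter.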